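A few compounds are considered here, and "the series" means these few. Any claim that something is new, unique, unknown or untested is made for them only; others in the source may bear on it.

Compounds with measured values:
- compound 1, `C=C1[C@@H](OC(C)=O)C[C@@H]2[C@](C)(CO[Si](C)(C)C(C)(C)C)[C@H](OC(C)=O)CC[C@@]2(C)[C@@H]1C[C@@H](Nc1ccc(Br)cc1)C1=CCOC1=O`: 4590 nM
- compound 2, `C=C1[C@@H](OC(C)=O)C[C@@H]2[C@](C)(COC=O)[C@H](OC(C)=O)CC[C@@]2(C)[C@@H]1C[C@@H](Nc1ccc(O)cc1)C1=CCOC1=O`: 13400 nM
- compound 3, `C=C1[C@@H](OC(C)=O)C[C@@H]2[C@](C)(COC=O)[C@H](OC(C)=O)CC[C@@]2(C)[C@@H]1C[C@@H](Nc1ccc(C(=O)O)cc1)C1=CCOC1=O`: 37200 nM

All three were tested in a functional assay on HT-29 cells (Homo sapiens) for cytotoxicity, read by sulforhodamine B assay; on this read-out lower numbers stand for stronger inhibition and higher numbers for weaker inhibition. Compound 1 gives the lowest of the three numbers, so it is the strongest inhibitor here; compound 2 gives a higher number and compound 3 the highest. Going by the values given here, the only step between two compounds differing in a single place is a 2.8-fold higher number from compound 2 to compound 3 (0.44 log units; beyond the scatter), and that step concerns carboxy replacing hydroxy, not the change considered next.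

Compound 4, `C=C1[C@@H](OC(C)=O)C[C@@H]2[C@](C)(CO[Si](C)(C)C(C)(C)C)[C@H](OC(C)=O)CC[C@@]2(C)[C@@H]1C[C@@H](Nc1ccc(OC)cc1)C1=CCOC1=O`, is not yet measured. It differs from compound 1 in one place: methoxy in place of bromo on an aromatic carbon. Among the compounds with values here, no measured pair shows a bromo replaced by a methoxy, so nothing here bears directly on this change; the step from compound 2 to compound 3 only shows that swapping one group at this aromatic carbon can move the number modestly. Within the data shown here, with no direct precedent, a small shift toward a higher number is expected, one that may well lie within the scatter. Compound 4 is therefore estimated at 7000 nM, with a range from 3000 nM to 16000 nM, which amounts to an expected step of a 1.5-fold higher number from compound 1 to compound 4 (0.18 log units; within the scatter).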

Compound 4, half-maximal inhibitory concentration: 5370 nM
Beside the measured number, compound 4's estimate is 1.3-fold (0.12 log units) above it, within the range that was stated.
By their numbers in this assay, from the lowest: compounds 1 and 4 (each within the scatter of the next); then compound 2; then compound 3.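

In this assay, going by these compounds alone, this is the first direct test of the group on this aromatic carbon with the rest of the molecule held constant, and putting methoxy in place of bromo gives a 1.2-fold higher number from compound 1 to compound 4 (0.07 log units; within the scatter). The two groups are not the same in make-up, since bromo has 1 heavy atom and 0 hydrogen-bond acceptors, while methoxy has 2 heavy atoms and 1 hydrogen-bond acceptor, yet this assay does not separate compound 1 from compound 4, unlike the earlier swap of hydroxy for carboxy, a 2.8-fold higher number from compound 2 to compound 3 (0.44 log units; beyond the scatter), made on a different version of the molecule. No measurement offered here explains why these two groups read alike.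

On these data alone, it remains open whether an amine, a nitrile or a longer chain such as ethoxy on this aromatic carbon would also stay within the scatter of compound 1. Compound 2 and compound 3 differ from compound 1 in more than one place, so what hydroxy or a carboxylic acid would do with the rest of compound 1 kept unchanged is also unresolved.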